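The source may report more compounds than this note shows. Statements on the series, on what has been measured and on what is new or still open speak of the compounds shown alone.

Compound 1 `Cc1cc(Nc2cc(N3CCN(C)CC3)nc(Nc3ccc(Cl)cc3)n2)n[nH]1` and compound 2 `COc1ccc(Nc2nc(Nc3cc(C)[nH]n3)cc(N3CCN(C)CC3)n2)cc1` share one core and differ only at a single aromatic carbon of a six-membered aromatic ring of carbon only. In a functional assay on PC-3 cells (Homo sapiens) for antiproliferative activity, read by CCK-8 assay, with a stated time of 72 h (a higher number here means a weaker inhibitor, a lower number a stronger inhibitor), compound 1 gives 1480 nM, and in this assay compound 2 gives 2000 nM. Going by the values given here, the only measured step, a 1.4-fold higher number from compound 1 to compound 2 (0.13 log units; within the scatter), is the whole picture so far, so compound 2 stands beside compound 1 with a gap that the usual scatter covers. Compound 3 `Cc1cc(Nc2cc(N3CCN(C)CC3)nc(Nc3ccc([N+](=O)[O-])cc3)n2)n[nH]1` differs from compound 2 by nitro in place of methoxy on an aromatic carbon. Among the compounds with values here, the one measured step that bears on an exchange of the group at this same aromatic carbon is a 1.4-fold higher number from compound 1 to compound 2 (0.13 log units; within the scatter), and it stayed within the scatter; on that basis no step beyond the scatter is expected for compound 3 in this assay, which means an estimated 1.1-fold lower number from compound 2 to compound 3 (0.05 log units; within the scatter). Compound 3 is therefore estimated at 1800 nM, with a likely range from 800 nM to 4000 nM.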

Compound 3, half-maximal inhibitory concentration: 1090 nM
For compound 3 the middle estimate is 1.7-fold (0.22 log units) above the measured one, and the stated range covers the measured number.
By their numbers in this assay, from the lowest: compounds 3, 1 and 2 (each within the scatter of the next).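

The aromatic carbon para to a large group has now carried chloro, methoxy and nitro, and one more exchange there leaves the reading in this assay unresolved from the others. The step of a 1.8-fold lower number from compound 2 to compound 3 (0.26 log units; within the scatter) and the step of a 1.4-fold lower number from compound 1 to compound 3 (0.13 log units; within the scatter) both stay inside the scatter, so nitro, with its three heavy atoms and two hydrogen-bond acceptors, cannot be told apart from either earlier group, and across these three compounds this position shows no measurable preference. Nothing available here offers an explanation for this flat picture.

As far as these compounds go, whether the same holds for an amine, a carboxylic acid or a longer chain at this carbon remains open. So does whether a bare hydrogen there would read any differently on the same shared core.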